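The source may report more compounds than this note shows. Statements on the series, on what has been measured and on what is new or still open speak of the compounds shown alone.

Values so far in a functional assay on A549 cells (Homo sapiens) for antiproliferative activity, with a stated time of 5 days (a higher number here means a weaker inhibitor, a lower number a stronger inhibitor), are:

- Compound 1 `COc1ccc(-n2nc(-c3ccc4ccccc4c3)nc2N2C(=O)COC23C=CC(=O)C=C3)cc1` gives 260 nM
- Compound 2 `O=C1C=CC2(C=C1)OCC(=O)N2c1nc(-c2ccc3ncccc3c2)nn1-c1ccccc1` gives 170 nM
- Compound 3 `O=C1C=CC2(C=C1)OCC(=O)N2c1nc(-c2ccc3ccccc3c2Br)nn1-c1ccccc1` gives 100 nM

Compound 3 (100 nM) cannot be told apart from compound 2 (170 nM) in this assay because the two lie within the usual scatter. Compound 1 (260 nM) has a higher number than compound 3, and that gap lies beyond the scatter.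

The next compound is compound 4 `O=C1C=CC2(C=C1)OCC(=O)N2c1nc(-c2ccc3ccccc3c2)nn1-c1ccccc1` which has hydrogen in place of bromo on an aromatic carbon. In other words, 1-bromonaphthalen-2-yl becomes naphthalen-2-yl.

For the measured compounds named here, no measured pair shows this change alone. The nearest evidence is a 1.7-fold lower number from compound 2 to compound 3 (0.23 log units; within the scatter) for 1-bromonaphthalen-2-yl in place of quinolin-6-yl. That swap moved the number very little, so a small step is expected here too. Compound 1 (260 nM) also carries naphthalen-2-yl but differs elsewhere in the molecule, which gives a weak hint that the number may drift upward. The expected step is a 1.6-fold higher number from compound 3 to compound 4 (0.20 log units; within the scatter) in this assay and is not expected to clearly exceed the scatter. Compound 4 is estimated at 160 nM with an expected range of 70 nM to 380 nM in this measurement.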

Compound 4, half-maximal inhibitory concentration: 140 nM
The estimate for compound 4 lay 1.1-fold (0.06 log units) above the measured number, and the stated range covers the measured number.
By their numbers in this assay, from the lowest: compounds 3, 4, 2 and 1 (each within the scatter of the next, the first and the last beyond it).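

In this assay, for the compounds shown here, this is the first direct reading of the bromo group on the 1-bromonaphthalen-2-yl ring: taking it away gives a 1.4-fold higher number from compound 3 to compound 4 (0.15 log units; within the scatter), so this aromatic carbon can carry either bromo or hydrogen with no change that can be told apart from the scatter. Compound 4 also provides two more single-change comparisons, a 1.2-fold lower number from compound 2 to compound 4 (0.08 log units; within the scatter), where naphthalen-2-yl replaces quinolin-6-yl, and a 1.9-fold lower number from compound 1 to compound 4 (0.27 log units; within the scatter), where hydrogen replaces methoxy, and since neither step exceeds the scatter, neither swap has a clear effect on the number in this series. Nothing available here offers an explanation for the size of these steps.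

Only bromo and hydrogen are shown on this aromatic carbon, so it remains open whether an amine, a carboxylic acid or a longer alkyl chain there would shift the number beyond the scatter. From the compounds shown here alone, it also remains open whether these small steps would stay as small in cells other than the one line tested here.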